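The source may report more compounds than this note shows. Statements on the series, on what has been measured and on what is new or still open speak of the compounds shown alone.

Compound 1 `COc1ccc(C2CC(c3ccco3)=NN2C(C)=O)cc1OC` gives 9990 nM
Compound 2 `O=CCN1N=C(c2ccc3ccccc3c2)CC1c1ccccc1` gives 8400 nM

Both values come from a functional assay on HEp-2 cells (Homo sapiens) for cytotoxicity, read by sulforhodamine B assay, with a stated time of 48 h (on this read-out lower numbers stand for stronger inhibition and higher numbers for weaker inhibition), and lie within the usual scatter of each other. On these numbers, compound 2 therefore stands level with compound 1, and neither can be called the stronger.

Compound 3 `O=CCN1N=C(c2ccc3ccccc3c2)CC1c1ccccc1[N+](=O)[O-]` is compound 2 with a single structural change, phenyl to 2-nitrophenyl: nitro in place of hydrogen on an aromatic carbon. In words, nitro replaces hydrogen on an aromatic carbon, ortho to a large group.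

Among the measured compounds shown here, no pair of measured compounds shows what a change of this kind does in this assay, so the data offer no direction for it. The expectation is no step beyond the scatter, perhaps with a slight lean towards stronger inhibition. The estimated 1.2-fold lower number from compound 2 to compound 3 (0.08 log units; within the scatter) is correspondingly small. For compound 3 the expected value is 7000 nM, with an estimated range from 2500 nM to 20000 nM, and the measurement is still to come.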

Compound 3, half-maximal inhibitory concentration: 3630 nM
Beside the measured number, compound 3's estimate is 1.9-fold (0.29 log units) above it; low and high end bracket the measured number.
By their numbers in this assay, from the lowest: compound 3; then compounds 2 and 1 (each within the scatter of the next).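

In this assay, nitro in place of hydrogen on an aromatic carbon, ortho to a large group, gives a 2.3-fold lower number from compound 2 to compound 3 (0.36 log units; beyond the scatter) and so moves the number towards stronger inhibition. Compounds 1 and 2 differ in more than one place and could not show this, whereas this pair gives the first sign that this place on the phenyl ring responds to a change, even if the step is only modest. No measurement at hand explains why the number moves.

A single pair cannot tell whether this step is specific to nitro or whether another group at this place, such as an amine or a carboxylic acid, would give a similar step. It also leaves open whether nitro would act the same way on the core of compound 1.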